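The source may hold more compounds than are shown below. What is called first, only, known or untested is meant among the compounds shown, and "the series" means these compounds.

Measured compounds:
- compound 1, `CN1CCN(c2ccc(C(=O)/C=C/c3ccc(Cl)cc3)cc2)CC1`: 102 ug/mL
- compound 2, `O=C(c1ccc(NC2CCCCC2)cc1)C1CC1c1ccc(Cl)cc1`: 196 ug/mL
- compound 3, `O=C(c1ccc(N2CCN(c3cccc(Cl)c3Cl)CC2)cc1)C1CC1c1ccc(Cl)cc1`: 383 ug/mL

All three numbers come from an ADME assay on Vero cells (Chlorocebus sabaeus) for cytotoxicity, with a stated time of 72 h; a lower number here means that less compound is tolerated, a higher number that more compound is tolerated. Compound 2 sits between the values of compound 1 and compound 3, and both of those gaps lie within the usual scatter of repeated measurements, so the three measured compounds are, for present purposes, indistinguishable in this assay. Among the measured compounds shown here, no pair of measured compounds differs at a single place, so no step between measured compounds is available to calibrate the change under consideration.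

The next compound, compound 4, `CN(C)c1ccc(C(=O)C2CC2c2ccc(Cl)cc2)cc1`, has not yet been measured in this assay. It differs from compound 2 as follows: dimethylamino in place of cyclohexylamino on an aromatic carbon

For the measured compounds named here, with no step of this type among the measured compounds, the only guide is the narrow spread of the three existing numbers. The expectation for this assay is therefore a step from compound 2 to compound 4 of no more than the scatter, in either direction, with a slight lean toward less compound being tolerated given the smaller group entering. Compound 4 is estimated at 150 ug/mL in this assay, with a range from 70 ug/mL to 320 ug/mL. The estimated step from compound 2 to compound 4 is a 1.3-fold lower number from compound 2 to compound 4 (0.12 log units; within the scatter).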

Compound 4, half-maximal cytotoxic concentration: 344 ug/mL
Estimate against measurement, compound 4: 2.3-fold (0.36 log units) below; measured number above the stated range.
By their numbers in this assay, from the lowest: compounds 1, 2, 4 and 3 (each within the scatter of the next, the first and the last beyond it).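

Working notes: in this assay, the first readable step at this position, an aromatic carbon para to a large group, is a 1.8-fold higher number from compound 2 to compound 4 (0.24 log units; within the scatter), so the two compounds cannot be told apart. Dimethylamino can therefore take the place of cyclohexylamino here, with the six-membered non-aromatic ring and the hydrogen-bond donor of the leaving group gone, without a readable difference in this read-out; this holds for this one pair only. Nothing available explains this outcome.

On these data alone, whether the same holds for a primary amine, a morpholine ring or a longer alkyl chain on this aromatic carbon remains open, as does the behaviour of a carboxylic acid there. Among the compounds shown here, compound 1 and compound 3 each differ from compound 2 and compound 4 in more than one place, so they offer no second step of this type, and whether the result carries over to another core remains unknown.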